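This account rests on a few compounds, and the source may have more. Where it says the series, first, only, none or still open, it means among the compounds named here.

Compound 3 `CCCC[S+]([O-])c1nc(N)c2nc(O)n(Cc3ccccc3)c2n1` gives in a functional assay (spleen, spleen) for activation, with Mus musculus as the target (a higher number here means that more compound is needed for the effect, a lower number that less compound is needed), the lowest of the three numbers recorded, 0.01 uM. Compound 1 `CCc1nc(N)c2nc(O)n(Cc3ccccc3)c2n1` gives in this assay 1 uM, and compound 2 `Cc1nc(N)c2nc(O)n(Cc3ccccc3)c2n1` gives in this assay 1 uM; the step of no change at the digits printed from compound 1 to compound 2 (within the scatter) lies within the scatter, so these two are not told apart. Both steps to compound 3 are large: a 100-fold lower number from compound 1 to compound 3 (2.00 log units; beyond the scatter) and a 100-fold lower number from compound 2 to compound 3 (2.00 log units; beyond the scatter).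

Compound 4 `Nc1nc(O)nc2c1nc(O)n2Cc1ccccc1` is not yet measured. The change from compound 3 is one oxygen atom in place of a group of 6 heavy atoms (4 carbon, 1 oxygen, 1 sulfur; no ring), on an aromatic carbon. This removes the very group whose arrival in the steps of a 100-fold lower number from compound 1 to compound 3 (2.00 log units; beyond the scatter) and a 100-fold lower number from compound 2 to compound 3 (2.00 log units; beyond the scatter) brought the large drop, and puts in its place a single atom, closer in size to what compound 2 carries at that position. Going by the values given here, no measured step speaks for the hydroxy group itself, so the expectation rests on the reversal of those two steps: a large rise in this assay is expected, of about the size seen in reverse, a 200-fold higher number from compound 3 to compound 4 (2.30 log units; beyond the scatter). Compound 4 is therefore estimated at 2 uM in this assay, within the range 0.3 uM to 20 uM.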

Compound 4, minimum effective concentration: 0.1 uM
For compound 4 the middle estimate is 20-fold (1.30 log units) above the measured one, outside the stated range (below it).
By their numbers in this assay, from the lowest: compound 3; then compound 4; then compounds 1 and 2 (each within the scatter of the next).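

At the aromatic carbon between two ring nitrogen atoms, the outcome does not follow the count of heavy atoms alone: hydroxy and methyl each bring a single heavy atom, yet in this assay the swap gives a 10-fold lower number from compound 2 to compound 4 (1.00 log units; beyond the scatter) and not a step within the scatter. Ethyl gives way to hydroxy with the same result, a 10-fold lower number from compound 1 to compound 4 (1.00 log units; beyond the scatter) here, so a group with oxygen on the ring carbon stands apart from both alkyl groups, which themselves could not be told apart. Loss of the group of compound 3 also costs less than its gain over those alkyl groups, with a 10-fold higher number from compound 3 to compound 4 (1.00 log units; beyond the scatter) as the step, which places hydroxy in the middle of the series.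

On these data alone, whether the low number of compound 3 comes from its butyl chain or from its sulfinyl link stays open, as does the standing of an amine, a methoxy group or a butoxy chain at this place. No data at hand account for any of these differences.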